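Triazole substituent changes on the shared core

The source may hold more compounds than are shown below. What is called first, only, known or untested is meant among the compounds shown, and "the series" means these compounds.

Compound 1 `O=c1cc(Cn2cc(C3CC3)nn2)c2ccc(O)cc2o1` sits at the limit (the limit of > 100000 nM in this assay, at which 1 of the 2 values shown sits); in a functional assay on SW-620 cells (Homo sapiens) for inhibition, read by MTT assay, with a stated time of 72 h (a lower number here means a stronger inhibitor, a higher number a weaker inhibitor), compound 1 gives > 100000 nM, a limit rather than a number. For the measured compounds named here, compound 2 `O=c1cc(Cn2cc(CCc3ccccc3)nn2)c2ccc(O)cc2o1` is the only member with a number: in this assay compound 2 gives 84400 nM. Going by the values given here, the step of an at least 1.1-fold lower number from compound 1 to compound 2 (0.07 log units; that floor lies within the scatter) is the sole measured step and stays within the scatter. Compound 3 `O=c1cc(Cn2cc(-c3ccc(Br)cc3)nn2)c2ccc(O)cc2o1` differs from compound 2 by 4-bromophenyl in place of phenethyl on an aromatic carbon. Among the compounds with values here, no measured step covers this change, and the one step from compound 1 to compound 2 gives no direction beyond the scatter, so no shift beyond the scatter is expected in this assay. Compound 3 is estimated at 70000 nM, within 25000 nM to 150000 nM. The expected step is then a 1.2-fold lower number from compound 2 to compound 3 (0.08 log units; within the scatter).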

Compound 3, half-maximal inhibitory concentration: 97700 nM
The estimate for compound 3 lay 1.4-fold (0.14 log units) below the measured number; the range from low to high includes it.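

In this assay, 4-bromophenyl in place of phenethyl on this aromatic carbon gives a 1.2-fold higher number from compound 2 to compound 3 (0.06 log units; within the scatter), so the assay does not separate these two large groups. The value for compound 1 is a limit and not a number, so the comparison with cyclopropyl reads only as a floor: an at least 1.0-fold lower number from compound 1 to compound 3 (0.01 log units; that floor lies within the scatter). No group shown here gives a number clearly apart from that limit: the limit of > 100000 nM in this assay, at which 1 of the 3 values shown sits.

From the compounds shown here alone, it remains open whether any group on this carbon can give a much lower number. An amine, a carboxylic acid or a longer chain would test this.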